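Swapping Methoxy for Methyl: Expected Cell Toxicity

The compounds below may be only part of what the source reports. "The series", "measured", "known", "first", "only" and "open" are said of these compounds alone.

Compound 1 `COc1ccccc1NC(=O)c1ccc2cccc(O)c2n1` gives > 30000 nM in an ADME assay on THP-1 cells (Homo sapiens) for cytotoxicity, read by WST assay, with a stated time of 24 h (on this read-out higher numbers stand for weaker inhibition and lower numbers for stronger inhibition), which is a limit of the assay rather than a number.
Compound 2 `COc1cccc(NC(=O)c2ccc3cccc(O)c3n2)c1` gives > 30000 nM in this assay, again a limit.
Compound 3 `COc1ccc(NC(=O)c2ccc3cccc(O)c3n2)cc1` gives > 30000 nM in this assay, also a limit.

All three measured compounds share one core and differ only in where a methoxy group sits on the ring that carries the amide nitrogen. Within the data shown here, none of them reaches a measurable number: every value stops at the limit of > 30000 nM in this assay, at which 3 of the 3 values shown sit, so compound 3 is not placed in any order among them, and no step between measured compounds can be drawn.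

Among the measured compounds shown here, the unmeasured compound 4 `Cc1ccc(NC(=O)c2ccc3cccc(O)c3n2)cc1` keeps the core of compound 3 and changes only one group: methyl in place of methoxy on an aromatic carbon, para to a large group.

For the measured compounds named here, with no measured step to lean on, the expectation rests on the fact that every measured compound sits at the limit. The change from compound 3 to compound 4 is expected to make no difference beyond the usual scatter in this assay, so a step that the limit leaves unreadable from compound 3 to compound 4 is the estimated step. Compound 4 is therefore expected to give about 40000 nM, with a plausible range from 15000 nM to 100000 nM, and most likely another limit rather than a number.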

Compound 4, half-maximal inhibitory concentration: > 30000 nM
Compound 4 was reported as a limit (the forecaster's own chance of this, stated with the estimate: 85%); the middle value lies beyond the limit too.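

Compound 3 and compound 4 both stop at a limit and not at a number, so no step between them can be read: the limit of > 30000 nM in this assay, at which 4 of the 4 values shown sit.

The compounds shown leave open whether methyl in place of methoxy, or a different place for the methoxy group, changes the value at all in this assay.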